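The source may report more compounds than this note shows. Statements on the series, on what has been measured and on what is new or still open speak of the compounds shown alone.

Series notes, amide variations on a diaryl-urea cinnamamide scaffold. All numbers come from a functional assay on A-375 cells (Homo sapiens) for inhibition, read by MTT assay, with a stated time of 120 h; a higher number here means a weaker inhibitor, a lower number a stronger inhibitor.

Measured so far:
compound 1, `C/C(=C\c1ccc(NC(=O)Nc2ccc(Cl)c(C(F)(F)F)c2)cc1)C(=O)NC(C)c1ccccc1`, this assay: > 50000 nM (a limit of the assay, not a number)
compound 2, `CC(NC(=O)C#Cc1ccc(NC(=O)Nc2cc(C(F)(F)F)ccc2Cl)cc1)c1ccccc1`, this assay: 30500 nM
compound 3, `O=C(/C=C/c1ccc(NC(=O)Nc2ccc(Cl)c(C(F)(F)F)c2)cc1)NC1CCC1`, this assay: 15400 nM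

Compound 3 holds the lowest of the two numbers shown. The gap between compound 3 and compound 2 is within the usual scatter, so the two cannot be ordered. For compound 1 only a limit is known: the limit of > 50000 nM in this assay, at which 1 of the 3 values shown sits.

The step followed here leads from compound 3 to compound 4, `CC(NC(=O)/C=C/c1ccc(NC(=O)Nc2ccc(Cl)c(C(F)(F)F)c2)cc1)c1ccccc1`. The difference is 1-phenylethyl in place of cyclobutyl on an amide-type nitrogen, in words 1-phenylethyl in place of cyclobutyl on an amide-type nitrogen. Among the compounds with values here, no measured pair shows this exact change, so only indirect reading is possible. Compound 2 also carries the 1-phenylethyl amide and gives 30500 nM in this assay. Compound 1, likewise with 1-phenylethyl, reaches only the limit already named. Against this background the change is expected to shift the number little, if at all, with a weaker rather than a stronger result the more likely direction. The expected step is a 1.4-fold higher number from compound 3 to compound 4 (0.15 log units; within the scatter). Compound 4 is estimated at 22000 nM in this assay, with a range of 7000 nM to 60000 nM.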

Compound 4, half-maximal inhibitory concentration: 20800 nM
For compound 4 the middle estimate is 1.1-fold (0.02 log units) above the measured one, and the stated range covers the measured number.
By their numbers in this assay, from the lowest: compounds 3, 4 and 2 (each within the scatter of the next). At a limit, above all of these: compound 1.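

At the amide-type nitrogen, 1-phenylethyl in place of cyclobutyl gives in this assay a 1.4-fold higher number from compound 3 to compound 4 (0.13 log units; within the scatter) and so replaces the earlier indirect reading of this position with a direct one. Cyclobutyl with its 4 heavy atoms and 1-phenylethyl with its 8 therefore cannot be ordered here, even though one brings a six-membered aromatic ring and the other a four-membered non-aromatic ring, so this single pair shows no need for either ring type at this position. Compound 1 is known only through a limit of the assay, not a number: the limit of > 50000 nM in this assay, at which 1 of the 4 values shown sits.

The compounds shown leave open whether a substituent with a different kind of function on this amide nitrogen, such as a chain ending in an amine or a carboxylic acid, would move the number beyond the scatter. Also open, going by these compounds, is how a longer straight alkyl chain or a plain benzyl group would read at this position on the same core, since only cyclobutyl and 1-phenylethyl can be compared directly here.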